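This account rests on a few compounds, and the source may have more. Where it says the series, first, only, none or still open, it means among the compounds named here.

Values so far in an ADME assay on HEK293 cells (Homo sapiens) for cytotoxicity, read by MTT assay, with a stated time of 72 h; on this read-out lower numbers stand for stronger inhibition and higher numbers for weaker inhibition:
- Compound 1 `Cc1ccc(C(=O)N2CCN(CC(=O)N3CCN(CCCc4c[nH]c5ccccc45)CC3)CC2)cc1` gives 159000 nM
- Compound 2 `COc1cccc(C(=O)N2CCN(CC(=O)N3CCN(CCCc4c[nH]c5ccccc45)CC3)CC2)c1` gives 143000 nM

For the measured compounds named here, compound 2 stands within the scatter of compound 1, the only other measured compound, so the two cannot be ranked. Compound 3 `O=C(CN1CCN(C(=O)c2cccc(Br)c2)CC1)N1CCN(CCCc2c[nH]c3ccccc23)CC1` differs from compound 2 at one place: bromo in place of methoxy on an aromatic carbon, with bromo in place of methoxy on an aromatic carbon. Going by the values given here, one measured step bears on this change, and only indirectly, since no measured compound carries bromo. That step is a 1.1-fold lower number from compound 1 to compound 2 (0.05 log units; within the scatter), with 3-methoxyphenyl in place of 4-methylphenyl on a carbonyl carbon. On this evidence, no step beyond the scatter is expected in this assay, in either direction. The expected step is a 1.1-fold lower number from compound 2 to compound 3 (0.04 log units; within the scatter). For compound 3 the estimated value is 130000 nM, with an expected range from 60000 nM to 250000 nM.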

Compound 3, half-maximal inhibitory concentration: 80700 nM
Beside the measured number, compound 3's estimate is 1.6-fold (0.21 log units) above it; low and high end bracket the measured number.
By their numbers in this assay, from the lowest: compounds 3, 2 and 1 (each within the scatter of the next).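

In this assay, bromo on this aromatic carbon, meta to a large group, gives a 1.8-fold lower number from compound 2 to compound 3 (0.25 log units; within the scatter) and so stays within the scatter of methoxy, even though a single bromine atom replaces a group of two heavy atoms that carries a hydrogen-bond acceptor. Changing both the substituent and its place on the ring gives a 2.0-fold lower number from compound 1 to compound 3 (0.29 log units; within the scatter) and also remains within the scatter, so the three compounds cannot be ranked and the 3-bromophenyl group opens no measurable gap from either earlier aryl group. Nothing measured on these compounds accounts for this result.

Going by these compounds, whether an amine or a carboxylic acid on this carbon would give a step beyond the scatter remains open. So does whether a longer chain there would leave the number within the scatter, as bromo and methoxy do.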